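Swapping Iodine for Bromine on a Shared Core

A few compounds are considered here, and "the series" means these few. Any claim that something is new, unique, unknown or untested is made for them only; others in the source may bear on it.

Of the compounds shown here, two built on the same core have so far been tested in a functional assay on MGC-803 cells (Homo sapiens) for inhibition, read by sulforhodamine B assay; a higher number here means a weaker inhibitor, a lower number a stronger inhibitor. Compound 1 `O=C1C=C(Nc2ccc(I)cc2)C(=O)c2c1nc1n2[C@H]2OC[C@@H](O)[C@H]2OC1` carries a (4-iodophenyl)amino group, and in this assay compound 1 gives 1400 nM, the lowest of the two numbers recorded. Compound 2 `COc1ccccc1NC1=CC(=O)c2c(nc3n2[C@H]2OC[C@@H](O)[C@H]2OC3)C1=O` is the other measured member, and in this assay compound 2 gives 1670 nM; the gap between compound 1 and compound 2 lies within the usual scatter of repeated measurements, so the two values show no difference that can be read as an order.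

Compound 3 `O=C1C=C(Nc2ccc(Br)cc2)C(=O)c2c1nc1n2[C@H]2OC[C@@H](O)[C@H]2OC1` has not yet been measured. It differs from compound 1 in one place: bromo in place of iodo on an aromatic carbon. Hydrogen-bond donors, acceptors and charge stay unchanged. For the measured compounds named here, no measured pair in this set shows what such an exchange does, so there is no step to lean on. The expected step is a 1.1-fold higher number from compound 1 to compound 3 (0.03 log units; within the scatter), nothing beyond the scatter in either direction. Compound 3 is therefore estimated to give 1500 nM in this assay, with a range from 700 nM to 3200 nM.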

Compound 3, half-maximal inhibitory concentration: 1010 nM
The estimate for compound 3 lay 1.5-fold (0.17 log units) above the measured number; low and high end bracket the measured number.
By their numbers in this assay, from the lowest: compounds 3, 1 and 2 (each within the scatter of the next).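

Bromo in place of iodo on an aromatic carbon para to a large group is the first change in this set that can be read as a single step, and in this assay it comes to a 1.4-fold lower number from compound 1 to compound 3 (0.14 log units; within the scatter) and so stays inside the usual scatter. At this position, then, the 4-bromophenyl and 4-iodophenyl groups are not told apart by this assay, and exchanging one of these two halogens for the other leaves the read-out without a difference that can be given an order. Nothing further is at hand that would speak to what lies behind this result.

The compounds shown leave open what happens when a chloro or fluoro group, or a group of another kind such as an amine or a carboxylic acid, stands on the same carbon in place of either halogen. They also leave open whether the two halogens stay equivalent on the same core in cells other than those used here.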